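Aryl exchange on the carbonyl carbon: compound 3

The compounds below may be only part of what the source reports. "The series", "measured", "known", "first", "only" and "open" are said of these compounds alone.

Compound 1 `CN(C(=O)NC(=O)c1ccc(Cl)cc1Cl)c1nc(C(F)(F)F)c(C(=O)N/N=C/c2ccccc2C(F)(F)F)s1` and compound 2 `CN(C(=O)NC(=O)c1c(Cl)cccc1Cl)c1nc(C(F)(F)F)c(C(=O)N/N=C/c2ccccc2C(F)(F)F)s1` share one core and differ only in the aryl attached to the carbonyl carbon. In a functional assay on HeLa cells (Homo sapiens) for inhibition, read by MTT assay, with a stated time of 72 h (a lower number here means a stronger inhibitor, a higher number a weaker inhibitor), compound 1 gives 9 ug/mL. In this assay, among the compounds with values here, compound 2 gives 5.23 ug/mL, the lowest of the two numbers so far, yet the step of a 1.7-fold lower number from compound 1 to compound 2 (0.24 log units; within the scatter) leaves the pair within the scatter, so no order between them can be read.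

Compound 3 `CN(C(=O)NC(=O)c1ccc(C(F)(F)F)cc1)c1nc(C(F)(F)F)c(C(=O)N/N=C/c2ccccc2C(F)(F)F)s1` is the next member. The change from compound 2 to compound 3 is 4-(trifluoromethyl)phenyl in place of 2,6-dichlorophenyl on a carbonyl carbon. Within the data shown here, the only measured step, a 1.7-fold lower number from compound 1 to compound 2 (0.24 log units; within the scatter), exchanged one dichlorophenyl for another and stayed within the scatter; it does not test a trifluoromethyl substituent on this ring and bears on the new step only loosely, as a sign that this aryl has already tolerated one exchange without a shift beyond the scatter. Among the measured compounds shown here, no measured step shows a trifluoromethyl placed here, so the expectation is a step of a 1.3-fold higher number from compound 2 to compound 3 (0.13 log units; within the scatter) that remains within the scatter, with a wide band around it. For compound 3 the estimate in this assay is 7 ug/mL, with a range of 2 ug/mL to 25 ug/mL.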

Compound 3, half-maximal inhibitory concentration: 3.76 ug/mL
Estimate against measurement, compound 3: 1.9-fold (0.27 log units) above; the measured number falls inside the stated range.
By their numbers in this assay, from the lowest: compounds 3, 2 and 1 (each within the scatter of the next, the first and the last beyond it).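

On the carbonyl carbon whose other neighbour is the amide-type nitrogen, the aryl has now accepted a group carrying trifluoromethyl instead of chlorine: in this assay the step, a 1.4-fold lower number from compound 2 to compound 3 (0.14 log units; within the scatter), gives no order between 4-(trifluoromethyl)phenyl and 2,6-dichlorophenyl. Against 2,4-dichlorophenyl the same group gives the only separation in the series that clears the scatter, a 2.4-fold lower number from compound 1 to compound 3 (0.38 log units; beyond the scatter), but it is modest, and compound 2 lies within the scatter of both other compounds, so 4-(trifluoromethyl)phenyl can be ranked ahead of 2,4-dichlorophenyl alone. No supporting data bear on the origin of either step.

All three aryl groups shown carry halogen, so it remains open how an unsubstituted phenyl, a methoxy-bearing phenyl, a pyridine ring or a phenyl bearing a carboxylic acid would read at this carbonyl carbon. Also open, from the compounds shown here alone, is whether a single chlorine would read like the trifluoromethyl group, and whether the trifluoromethyl group would hold this reading at another place on the phenyl ring.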